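The source may report more compounds than this note shows. Statements on the series, on what has been measured and on what is new or still open speak of the compounds shown alone.

Compound 1 `COc1cc2c(Nc3nc4ccc(C(=O)Nc5c(C)cccc5C)cc4s3)ncnc2cc1OCCCN1CCCC1` in a functional assay on A549 cells (Homo sapiens) for cytotoxicity, read by WST assay, with a stated time of 72 h (a higher number here means a weaker inhibitor, a lower number a stronger inhibitor), gives 83800 nM, the only result in the series that is a number rather than a limit. Compound 2 `COc1cc2c(Nc3nc4ccc(C(=O)Nc5c(C)cccc5C)cc4s3)ncnc2cc1OCCCN1CCCCC1` in this assay reports only a limit, > 100000 nM. Going by the values given here, the one measured step, an at least 1.1-fold higher number from compound 1 to compound 2 (0.07 log units; that floor lies within the scatter), touches the amine at the end of the chain and is bounded by the limit of > 100000 nM in this assay, at which 1 of the 2 values shown sits. Compound 3 `COc1cc2c(Nc3nc4ccc(C(=O)Nc5c(C)cccc5Cl)cc4s3)ncnc2cc1OCCCN1CCCC1` differs from compound 1 elsewhere: chloro in place of methyl on an aromatic carbon. Among the compounds with values here, no measured step touches that part of the molecule, so no shift beyond the scatter is expected, a 1.0-fold lower number from compound 1 to compound 3 (0.02 log units; within the scatter). Compound 3 is therefore estimated at 80000 nM, within 35000 nM to 180000 nM.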

Compound 3, half-maximal inhibitory concentration: 38600 nM
Compound 3: middle estimate off by 2.1-fold (0.32 log units), on the high side; the range from low to high includes it.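

The aryl end of the amide, untouched by the earlier step, does respond in this assay: chloro in place of methyl gives a 2.2-fold lower number from compound 1 to compound 3 (0.34 log units; beyond the scatter) and the shift is modest. This is the only step shown with a number on both sides, as the amine step rests on a limit. Nothing at hand gives a cause for this shift.

From the compounds shown here alone, whether fluoro or methoxy at the same place, or a 2,6-dichlorophenyl group, moves the number further stays open. So does whether the chloro change holds with piperidin-1-yl at the chain end.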